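Adding fluorine to the benzyl ring of a chromone amide

The source may hold more compounds than are shown below. What is called first, only, known or untested is meant among the compounds shown, and "the series" means these compounds.

Measured so far:
compound 1, `COc1ccc2c(=O)c(/C=C/C(=O)NCc3ccccc3)coc2c1`: 11800 nM
compound 2, `COc1ccc2c(=O)c(/C=C/C(=O)NCc3ccc(C)cc3)coc2c1`: > 100000 nM

Among the measured compounds shown here, in a functional assay on A549 cells (Homo sapiens) for inhibition, read by MTT assay, with a stated time of 48 h (on this read-out lower numbers stand for stronger inhibition and higher numbers for weaker inhibition), compound 1 gives 11800 nM, the only actual number here. Compound 2 reaches only the assay limit of > 100000 nM, so its value is a limit, not a number (the limit of > 100000 nM in this assay, at which 1 of the 2 values shown sits). The shift an at least 8.4-fold higher number from compound 1 to compound 2 (0.92 log units; beyond the scatter) shows that substituting the phenyl of compound 1 weakened inhibition. Compound 3, `COc1ccc2c(=O)c(/C=C/C(=O)NCc3ccc(F)cc3F)coc2c1`, carries the change (2,4-difluorophenyl in place of phenyl on a saturated chain carbon bound to an amide-type nitrogen). Because the measured step of an at least 8.4-fold higher number from compound 1 to compound 2 (0.92 log units; beyond the scatter) was weakening, a weaker result is expected here too, though fluorine is a different group than methyl. For compound 3 the estimated step is a 2.1-fold higher number from compound 1 to compound 3 (0.33 log units; beyond the scatter), giving an expected 25000 nM, with a range from 8000 nM to 100000 nM.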

Compound 3, half-maximal inhibitory concentration: 13300 nM
Compound 3: the middle estimate sits 1.9-fold (0.27 log units) above what was measured; measured number inside the range.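

The 2,4-difluorophenyl group in place of phenyl gives a 1.1-fold higher number from compound 1 to compound 3 (0.05 log units; within the scatter) and so no difference beyond the scatter, which means that adding groups to this ring need not weaken inhibition. In place of 4-methylphenyl, the same group gives an at least 7.5-fold lower number from compound 2 to compound 3 (0.87 log units; beyond the scatter) and so shows that the choice of group on this ring matters. Compound 2 stands at a limit, not a number: the limit of > 100000 nM in this assay, at which 1 of the 3 values shown sits.

Still open, on these data alone, is whether a single fluorine, a chlorine or a methoxy group on this ring would behave like the 2,4-difluorophenyl or the 4-methylphenyl group.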